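Adding a Ring Double Bond to a Potent Antagonist

The compounds below may be only part of what the source reports. "The series", "measured", "known", "first", "only" and "open" are said of these compounds alone.

Compound 3 `CC(C(=O)NCc1ccc(C(F)(F)F)nc1C1CCC(C)(C)CC1)c1ccc(NS(C)(=O)=O)c(F)c1` gives 0.4 nM in an assay on CHO cells for antagonist activity at transient receptor potential cation channel subfamily V member 1 (Homo sapiens), read by FLIPR and calcium flux (a higher number here means a weaker inhibitor, a lower number a stronger inhibitor), the highest of the three numbers shown, though every gap to the others lies within the scatter. Compound 2 `C[C@H](C(=O)NCc1ccc(C(F)(F)F)nc1C1CCC(C)(C)CC1)c1ccc(NS(C)(=O)=O)c(F)c1` gives 0.3 nM in this assay, and compound 1 `CCC1CCC(c2nc(C(F)(F)F)ccc2CNC(=O)[C@@H](C)c2ccc(NS(C)(=O)=O)c(F)c2)CC1` gives 0.2 nM. The step of a 1.5-fold higher number from compound 1 to compound 2 (0.18 log units; within the scatter) and the step of a 1.3-fold higher number from compound 2 to compound 3 (0.12 log units; within the scatter), which rests on (the fact that one of compounds 2 and 3 is drawn with a defined configuration and the other without, at the place where they differ), were both small. Compound 4 `CC(C(=O)NCc1ccc(C(F)(F)F)nc1C1=CCC(C)(C)CC1)c1ccc(NS(C)(=O)=O)c(F)c1` differs from compound 3 by 4,4-dimethylcyclohex-1-en-1-yl in place of 4,4-dimethylcyclohexyl on an aromatic carbon. Neither measured step touches the saturation of this ring; no shift beyond the scatter is expected from it. The expected step of a 1.3-fold higher number from compound 3 to compound 4 (0.10 log units; within the scatter) is small. Compound 4 is estimated at 0.5 nM, with a range from 0.2 nM to 1.5 nM.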

Compound 4, inhibition constant: 0.2 nM
For compound 4 the middle estimate is 2.5-fold (0.40 log units) above the measured one, and the stated range covers the measured number.
By their numbers in this assay, from the lowest: compounds 1, 4, 2 and 3 (each within the scatter of the next).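

In this assay, putting 4,4-dimethylcyclohex-1-en-1-yl in place of 4,4-dimethylcyclohexyl at this position, next to the ring nitrogen, gives a 2.0-fold lower number from compound 3 to compound 4 (0.30 log units; within the scatter). The earlier compounds shown here changed only the ring's alkyl groups and the drawn configuration, whereas this pair shows that a double bond in the ring leaves the number within the scatter. Nothing in the data shown explains this result.

Still open, as far as these compounds go, is how a flat phenyl ring or a piperidine ring would read at this position, and how compound 4 would read with its chain stereocentre drawn S.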